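Trimethoxyphenyl in place of methylphenyl on a quinazoline-type amine

The compounds below may be only part of what the source reports. "The series", "measured", "known", "first", "only" and "open" are said of these compounds alone.

Measured so far:
compound 1 `O=C(CSc1nc(Nc2ccccc2)c2ccccc2n1)Nc1ccccc1F`: 12400 nM
compound 2 `C=CC(=O)Nc1cccc(NC(=O)CSc2nc(Nc3ccccc3C)c3ccccc3n2)c1`: 23200 nM

In a functional assay on PC-3 cells (Homo sapiens) for inhibition, read by MTT assay, with a stated time of 72 h (on this read-out higher numbers stand for weaker inhibition and lower numbers for stronger inhibition), compound 2 gives 23200 nM, and compound 1 gives 12400 nM. The gap between the two lies within the usual scatter, so the numbers show no difference in strength.

Compound 3 `C=CC(=O)Nc1cccc(NC(=O)CSc2nc(Nc3cc(OC)c(OC)c(OC)c3)c3ccccc3n2)c1` differs from compound 2 in one place: 3,4,5-trimethoxyphenyl in place of 2-methylphenyl on a nitrogen on an aromatic ring.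

Within the data shown here, no step between measured compounds covers this change, so there is nothing to show its size in this assay. The expectation is a step from compound 2 to compound 3 that stays within the scatter, with no direction favoured: a 1.2-fold lower number from compound 2 to compound 3 (0.06 log units; within the scatter). Compound 3 is therefore estimated at 20000 nM, in a range from 7000 nM to 60000 nM.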

Compound 3, half-maximal inhibitory concentration: > 50000 nM
Compound 3: a limit, no number; the forecaster's own chance of this, stated with the estimate: 15%; middle value at least 2.5-fold (0.39 log units) from the limit.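

In this assay compound 3 gives > 50000 nM as a limit, not a number. Even so, the limit gives a direction: 3,4,5-trimethoxyphenyl in place of 2-methylphenyl on this nitrogen brings an at least 2.1-fold higher number from compound 2 to compound 3 (0.33 log units; beyond the scatter) and so weaker inhibition. Among these compounds, compound 1 and compound 2 differ in more than one place, so this is the first view of this position alone.

Going by these compounds, the true size of the step stays unknown, as does which of the three methoxy groups counts. On these data alone, whether a phenyl ring carrying a single methoxy or an amine would keep the strength of compound 2 also stays open.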